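This account rests on a few compounds, and the source may have more. Where it says the series, first, only, none or still open, it means among the compounds named here.

Results so far in a functional assay on MGC-803 cells (Homo sapiens) for cytotoxicity, read by MTT assay, with a stated time of 48 h; on this read-out lower numbers stand for stronger inhibition and higher numbers for weaker inhibition
- compound 1 `Cc1ccc(C(=O)N2N=C(c3cc4ccccc4oc3=O)CC2c2ccccc2)cc1` gives 31300 nM
- compound 2 `O=C(c1ccccc1Cl)N1N=C(c2cc3ccccc3oc2=O)CC1c1ccccc1` gives 6640 nM
- compound 3 `O=C(CN1CCCC1)N1N=C(c2cc3ccccc3oc2=O)CC1c1ccccc1` gives "not active" (no number reported)

Compound 3 has no number, so it cannot be placed on the scale alongside the other two. Compound 4 `O=C(CN1CCC(O)CC1)N1N=C(c2cc3ccccc3oc2=O)CC1c1ccccc1` differs from compound 3 in one place: 4-hydroxypiperidin-1-yl in place of pyrrolidin-1-yl on a saturated chain carbon bound to a carbonyl carbon In words, 4-hydroxypiperidin-1-yl replaces pyrrolidin-1-yl on a saturated chain carbon bound to a carbonyl carbon.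

Going by the values given here, the only measured step, a 4.7-fold lower number from compound 1 to compound 2 (0.67 log units; beyond the scatter), concerns a different pair of groups, so it is a loose guide. Among the compounds with values here, it shows only that a swap in this part of the molecule can shift the number. No step size can be stated from compound 3, but a weak result remains likely, near compound 1 at 31300 nM and possibly without any number. For compound 4 the expected value is about 30000 nM, with an estimated range of 8000 nM to 100000 nM.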

Compound 4, half-maximal inhibitory concentration: "not active" (no number reported)
For compound 4 the study gives words and no number; the estimate stays without a comparison.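

In this assay compound 3 and compound 4 are both reported only as not active, so no step can be read between them. No measurement shown offers an explanation for this result. Still open, going by these compounds, is how 4-hydroxypiperidin-1-yl and pyrrolidin-1-yl compare, since neither compound has a number.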